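The source may report more compounds than this note shows. Statements on the series, on what has been measured and on what is new or still open speak of the compounds shown alone.

Measured so far:
- compound 1, `COc1ccc(NCc2nc3ccccc3[nH]2)cc1`: 26.6%
- compound 2, `COc1ccc(NCc2nc3ccc(Br)cc3[nH]2)cc1`: 13.3%

In a functional assay on the whole organism (strain albino) for inhibition, with Rattus norvegicus as the target, read by paw edema, with a stated time of 60 min, at a dose of 100 mg/kg by the oral route (a higher number here means more inhibition at the dose given (going by the name of the read-out), a lower number less inhibition), compound 1 gives 26.6%, the higher of the two numbers measured. Within the data shown here, compound 2 gives 13.3%; the single measured step, a number 13.3 percentage points lower from compound 1 to compound 2 (beyond the scatter), goes with bromo in place of hydrogen on an aromatic carbon of the shared core.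

Compound 3, `Brc1ccc(NCc2nc3ccccc3[nH]2)cc1`, differs from compound 1 by bromo in place of methoxy on an aromatic carbon. Among the measured compounds shown here, no measured step removes a methoxy, and the one step that adds a bromo puts it on a different ring, so it bears only loosely on this change. It does show that a bromo entering the shared core cost something, and nothing in the data points upward, so a step downward that may or may not exceed the scatter seems the fairest expectation.

Compound 3 is therefore estimated at 19%, with a range from 7% to 32%, meaning an expected step of a number 7.6 percentage points lower from compound 1 to compound 3 (within the scatter).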

Compound 3, a percentage reported as inhibition, in the whole organism at one dose (the size of the read-out at that dose, not a potency): 13.3%
Beside the measured number, compound 3's estimate is 5.7 percentage points above it; the measured number falls inside the stated range.
By their numbers in this assay, from the lowest: compounds 2 and 3 (each within the scatter of the next); then compound 1.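

Among these compounds, until now, the only measured change lay elsewhere on the shared core; this one is at the aromatic carbon para to a large group, and it shows that this site also affects the read-out. In this assay, putting bromo in place of methoxy gives a number 13.3 percentage points lower from compound 1 to compound 3 (beyond the scatter), so at this site methoxy is not interchangeable with bromo. The swap removes two heavy atoms and one hydrogen-bond acceptor and brings in one bromine, and no measurement at hand explains the drop.

The compounds shown do not reveal which feature of the methoxy matters, or whether a hydroxy, an ethoxy or an amine at this carbon would keep or raise the number. On these data alone, it also remains open how a fluoro or chloro would compare with bromo here.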